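This account rests on a few compounds, and the source may have more. Where it says the series, first, only, none or still open, it means among the compounds named here.

Measured in a functional assay on HepG2 cells (Homo sapiens) for antiproliferative activity, read by MTT assay, with a stated time of 48 h; a higher number here means a weaker inhibitor, a lower number a stronger inhibitor:
- compound 1 `COc1ccc(C2OC(c3ccc4ccccc4c3)=NN2C(C)=O)cc1`: 3.6 ug/mL
- compound 2 `CC(=O)N1N=C(c2ccc3ccccc3c2)OC1c1ccc(Br)cc1`: 2.08 ug/mL

Only these two compounds have been measured so far. Compound 2, at 2.08 ug/mL, lies within the scatter of compound 1, at 3.6 ug/mL, so the two cannot be ranked.

The next compound, compound 3 `CC(=O)N1N=C(c2ccc3ccccc3c2)OC1c1ccccc1Cl`, carries 2-chlorophenyl in place of 4-bromophenyl on a saturated ring carbon. The shared core and its acetyl group stay as they are.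

Among the measured compounds shown here, only one measured step bears on this change: a 1.7-fold lower number from compound 1 to compound 2 (0.24 log units; within the scatter). It exchanges methoxy for bromo on an aromatic carbon of the same aryl group, and it stays within the scatter. For the measured compounds named here, that step gives a modest guide at best, since no measured compound carries chlorine or a substituent at another place on this ring. No step beyond the scatter is therefore expected in this assay, and no direction can be argued with confidence.

The expected change is a 1.2-fold higher number from compound 2 to compound 3 (0.08 log units; within the scatter). For compound 3 the estimated value is 2.5 ug/mL, with an expected range from 1 ug/mL to 6 ug/mL.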

Compound 3, half-maximal inhibitory concentration: 4.32 ug/mL
Beside the measured number, compound 3's estimate is 1.7-fold (0.24 log units) below it; measured number inside the range.
By their numbers in this assay, from the lowest: compounds 2, 1 and 3 (each within the scatter of the next, the first and the last beyond it).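

In this assay, among the compounds shown here, placing 2-chlorophenyl on the saturated ring carbon in place of 4-bromophenyl gives a 2.1-fold higher number from compound 2 to compound 3 (0.32 log units; beyond the scatter) and so provides the first step at this position that lies beyond the scatter, though only modestly. The aryl group on this carbon can therefore separate two compounds in this assay, which the methoxy-to-bromo exchange between compound 1 and compound 2 did not show. The separation does not extend to 4-methoxyphenyl: the exchange for 2-chlorophenyl gives a 1.2-fold higher number from compound 1 to compound 3 (0.08 log units; within the scatter) and leaves compound 1 and compound 3 unranked, so only compound 2 and compound 3 stand apart.

Nothing available here accounts for the step from 4-bromophenyl to 2-chlorophenyl.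

This change alters both the halogen and its place on the ring, so the compounds shown cannot assign the step to either; 4-chlorophenyl or 2-bromophenyl would be needed to separate the two. Going by these compounds, it also remains open how an amine or a carboxylic acid on this aryl ring would read in this assay, or whether a longer chain in place of the acetyl group would shift these values.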